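From Chloro to Dimethylamino, Tested a Second Time

The source may hold more compounds than are shown below. What is called first, only, known or untested is meant among the compounds shown, and "the series" means these compounds.

Of the compounds shown here, three of one series have been measured in a functional assay on HL-60 cells (Homo sapiens) for cytotoxicity, with a stated time of 24 h; on this read-out higher numbers stand for lower toxicity in this test and lower numbers for higher toxicity in this test. Compound 1 `O=C1/C(=C/c2ccc(Cl)cc2)CCC/C1=C\c1cccc([N+](=O)[O-])c1` gives 3200 nM in this assay. Compound 2 `CN(C)c1ccc(/C=C2\CCC/C(=C\c3cccc([N+](=O)[O-])c3)C2=O)cc1` differs from compound 1 in one place, (dimethylamino in place of chloro on an aromatic carbon), and in this assay compound 2 gives 30000 nM; the step is a 9.4-fold higher number from compound 1 to compound 2 (0.97 log units; beyond the scatter).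

Compound 3 `O=C1/C(=C/c2ccc(Cl)cc2)CCC/C1=C\c1ccc([N+](=O)[O-])cc1` is built from the same atoms as compound 1, joined differently, and the difference between the two cores is not broken down here. In this assay compound 3 gives 4100 nM, a value that lies within the usual scatter of the value of compound 1, while its gap to the value of compound 2 is beyond the scatter.

Compound 4 `CN(C)c1ccc(/C=C2\CCC/C(=C\c3ccc([N+](=O)[O-])cc3)C2=O)cc1` stands to compound 3 as compound 2 stands to compound 1: dimethylamino in place of chloro on an aromatic carbon, with the same surroundings at the place of exchange, so the change is the same one seen once already; among these compounds it occurs twice in all. For the measured compounds named here, with only one earlier instance to rest on, the step from compound 3 to compound 4 in this assay is expected to be of similar size, an 8.5-fold higher number from compound 3 to compound 4 (0.93 log units; beyond the scatter), and this expectation rests on the step of a 9.4-fold higher number from compound 1 to compound 2 (0.97 log units; beyond the scatter). Compound 4 is therefore estimated to give about 35000 nM in this assay. The estimate for compound 4 is expected to fall between 15000 nM and 80000 nM.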

Compound 4, half-maximal cytotoxic concentration: > 400000 nM
Compound 4 ended at the assay's limit; the forecaster's own chance of this, stated with the estimate: 20%; at least 11-fold (1.05 log units) between middle value and limit.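

Carried onto the core of compound 3, the exchange of chloro for dimethylamino again gave a higher number in this assay, with an at least 97-fold higher number from compound 3 to compound 4 (1.98 log units; beyond the scatter), but the two steps differ in size: the same change on two cores in this assay, a 9.4-fold higher number (0.97 log units; beyond the scatter) from compound 1 to compound 2 and an at least 97-fold higher number (1.98 log units; beyond the scatter) from compound 3 to compound 4, at least 10-fold (1.01 log units) apart, beyond the scatter of two such steps. Compound 4 stands at a limit of the assay and not at a number: the limit of > 400000 nM in this assay, at which 1 of the 4 values shown sits. With dimethylamino in both compounds, 4-nitrophenyl in place of 3-nitrophenyl gives an at least 13-fold higher number from compound 2 to compound 4 (1.12 log units; beyond the scatter), while in the chloro pair compound 1 at 3200 nM and compound 3 at 4100 nM lie within the scatter of each other, so the direction of the exchange held on both cores and its size did not, and these four compounds do not show why or what it would do on any further core.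

The compounds shown leave open how a plain amino group or a methoxy group in the place of dimethylamino would read on each of the two cores. They also leave open whether the gap between the two steps would persist with a nitrile in the place of the nitro group.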